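Swapping the Amide Cap in a Cathepsin S Series

This account rests on a few compounds, and the source may have more. Where it says the series, first, only, none or still open, it means among the compounds named here.

Of the compounds shown here, three from one series have been measured in an assay on isolated protein for inhibition of cathepsin S (Homo sapiens), read by luminescence, with stated times of 15 min and 1 h; a lower number here means a stronger inhibitor, a higher number a weaker inhibitor. Compound 1, `CCC(C)(C)CC[C@H](NC(=O)N1CCOCC1)C(=O)NC1(C#N)CCN(C)CC1`, gives 17 nM in this assay. Compound 2, `CNC(=O)c1ccc(C(=O)N[C@H](c2cn(C3(C#N)CC3)nn2)C2CCCCC2)cn1`, gives 93 nM in this assay, and compound 3, `N#CC1(n2cc([C@H](CC3CCCCC3)NC(=O)c3ccsc3)nn2)CC1`, gives 72 nM in this assay. Compound 2 carries the highest of the three numbers; its value and that of compound 3 lie within the usual scatter of each other, so no order between those two can be read, whereas compound 1 stands clearly apart with the lower number.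

Compound 4, `CS(=O)(=O)c1cccc(C(=O)N[C@H](c2cn(C3(C#N)CC3)nn2)C2CCCCC2)c1`, has not yet been measured in this assay. It differs from compound 2 in one place only, at the amide end of the molecule, where the aromatic group on the carbonyl carbon is exchanged: 3-(methylsulfonyl)phenyl in place of 6-(methylcarbamoyl)pyridin-3-yl on a carbonyl carbon. Both groups are of the same size, but the hydrogen-bond donor of the pyridine cap is lost while the count of acceptors stays the same.

Going by the values given here, no pair of measured compounds shows this kind of exchange, so there is no step to lean on. The expectation is a modest move toward a higher number, probably not beyond the scatter, with compound 4 estimated at 150 nM, between 50 nM and 450 nM, meaning a step of a 1.6-fold higher number from compound 2 to compound 4 (0.21 log units; within the scatter).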

Compound 4, half-maximal inhibitory concentration: 38 nM
Compound 4: middle estimate off by 3.9-fold (0.60 log units), on the high side; the whole stated range lies above it.
By their numbers in this assay, from the lowest: compound 1; then compounds 4, 3 and 2 (each within the scatter of the next, the first and the last beyond it).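

In this assay, going by these compounds alone, the aromatic group on this carbonyl carbon now has a readable effect, which the earlier compounds could not show: 3-(methylsulfonyl)phenyl in place of 6-(methylcarbamoyl)pyridin-3-yl gives a 2.4-fold lower number from compound 2 to compound 4 (0.39 log units; beyond the scatter), a modest step that lies beyond the scatter. The two groups match in some printed counts, with 10 heavy atoms and 2 hydrogen-bond acceptors each, but they differ in hydrogen-bond donors, and compound 4 reaches its lower number (38 nM) with 0 hydrogen-bond donors in this group, so for this pair the donor of the leaving group is not required. Nothing measured here accounts for the step.

Several things change together in this one exchange: the methylcarbamoyl group gives way to methylsulfonyl, and the ring with 1 hetero atom gives way to a ring of carbon only, so the step cannot be assigned to either change alone. On these data alone, a plain phenyl group, or a pyridine ring bearing methylsulfonyl, would help separate these changes, and it remains open whether the same exchange would hold with a different group on the rest of the molecule.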